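Replacing 2-fluorophenyl with 3-nitrophenyl in the trifluoromethyl compound

This account rests on a few compounds, and the source may have more. Where it says the series, first, only, none or still open, it means among the compounds named here.

Measured so far in a functional assay on THP-1 cells (Homo sapiens) for cytotoxicity, read by MTT assay, with a stated time of 24 h; a lower number here means a stronger inhibitor, a higher number a weaker inhibitor:
- compound 1 `CN1C/C(=C\c2ccc(C(C)(C)C)cc2)C(=O)/C(=C/c2ccccc2F)C1` gives 13400 nM
- compound 2 `CN1C/C(=C\c2ccc(C(F)(F)F)cc2)C(=O)/C(=C/c2ccccc2F)C1` gives 5930 nM
- compound 3 `CN1C/C(=C\c2ccc(C#N)cc2)C(=O)/C(=C/c2ccccc2F)C1` gives 810 nM

Compound 2 holds the second highest of the three numbers, and compound 3 lies lowest, with a 7.3-fold lower number from compound 2 to compound 3 (0.86 log units; beyond the scatter) separating them. Compound 4 `CN1C/C(=C\c2ccc(C(F)(F)F)cc2)C(=O)/C(=C/c2cccc([N+](=O)[O-])c2)C1` keeps the trifluoromethyl group of compound 2, and the single difference is 3-nitrophenyl in place of 2-fluorophenyl on a double-bonded chain carbon bound to a double-bonded ring carbon. Thus 3-nitrophenyl stands in place of 2-fluorophenyl on a double-bonded chain carbon bound to a double-bonded ring carbon.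

Going by the values given here, no measured step touches this position, since all three compounds carry 2-fluorophenyl. Among the compounds with values here, the only guidance is indirect: changes at the other aromatic group reached as far as a 17-fold lower number from compound 1 to compound 3 (1.22 log units; beyond the scatter) in this series. A modest step to a lower number is therefore expected in this assay, though with little confidence in its direction. The estimated change is a 2.4-fold lower number from compound 2 to compound 4 (0.38 log units; beyond the scatter) in this assay. For compound 4 the estimated value is 2500 nM, with an expected range of 700 nM to 8000 nM here.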

Compound 4, half-maximal inhibitory concentration: 970 nM
Estimate against measurement, compound 4: 2.6-fold (0.41 log units) above; the range from low to high includes it.
By their numbers in this assay, from the lowest: compounds 3 and 4 (each within the scatter of the next); then compound 2; then compound 1.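

In this assay, 3-nitrophenyl in place of 2-fluorophenyl gives a 6.1-fold lower number from compound 2 to compound 4 (0.79 log units; beyond the scatter), so this position, held constant across compounds 1 to 3, also bears on the number. Starting from compound 2, this step carries the same modest grade as a 7.3-fold lower number from compound 2 to compound 3 (0.86 log units; beyond the scatter), which is made at the other aromatic group, so changes at either group can shift the number beyond the scatter. Nothing available accounts for the effect of this change.

This single step alters both the substituent and its ring location, and the compounds shown do not separate the two; 3-fluorophenyl or 3-aminophenyl at this place would bear on that question. Also open, going by these compounds, is whether the two steps combine in a compound carrying both nitrile and 3-nitrophenyl.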